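The source may report more compounds than this note shows. Statements on the series, on what has been measured and on what is new or still open speak of the compounds shown alone.

Compound 2, with the structure `CCCOC(=O)C1=C(C)NC(C)=C(C(=O)OCC)C1c1[nH]cnc1Cl`, belongs to a small set of dihydropyridine esters tested in an assay on isolated protein for inhibition of Voltage-dependent L-type calcium channel subunit alpha-1C (Cavia porcellus); a higher number here means a weaker inhibitor, a lower number a stronger inhibitor. In this assay compound 2 gives 407 nM. Among the compounds with values here, the only other measured member is compound 1, with the structure `COC(=O)C1=C(C)NC(C)=C(C(=O)OCC2CCCCC2)C1c1[nH]cnc1Cl`, which in this assay gives 355 nM. The two numbers lie within the usual scatter of one another, so compound 2 and compound 1 cannot be told apart on potency, and neither can be called the stronger inhibitor.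

Compound 3, with the structure `CCOC(=O)C1=C(C)NC(C)=C(C(=O)OCC2CCCCC2)C1c1[nH]cnc1Cl`, has not yet been measured. It differs from compound 2 in one place: cyclohexyl in place of ethyl on a saturated chain carbon bound to an oxygen next to a carbonyl group. This brings the ester side of compound 3 in line with that of compound 1, while the other ester is one carbon longer than in compound 1.

Within the data shown here, no measured pair shows what this change alone does. Because compound 1, which carries the same cyclohexylmethyl ester, gives 355 nM, compound 3 is expected to land near both measured compounds. The step from compound 2 to compound 3 is estimated at a 1.4-fold lower number from compound 2 to compound 3 (0.13 log units; within the scatter), no larger than the scatter. Compound 3 is estimated at 300 nM, with a likely range from 120 nM to 750 nM.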

Compound 3, half-maximal inhibitory concentration: 513 nM
Beside the measured number, compound 3's estimate is 1.7-fold (0.23 log units) below it, within the range that was stated.
By their numbers in this assay, from the lowest: compounds 1, 2 and 3 (each within the scatter of the next).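

In this assay, cyclohexyl in place of ethyl on a saturated chain carbon bound to an oxygen next to a carbonyl group gives a 1.3-fold higher number from compound 2 to compound 3 (0.10 log units; within the scatter). Swapping propyl for cyclohexylmethyl, a chain for a ring of carbon only, therefore has no effect that can be told apart from the scatter of repeated measurements. A much smaller edit, methyl in place of hydrogen on a saturated chain carbon bound to an oxygen next to a carbonyl group, gives a 1.4-fold higher number from compound 1 to compound 3 (0.16 log units; within the scatter), so it too cannot be told apart from the scatter. No measurement shown here offers an explanation for how close these numbers lie.

As far as these compounds go, whether an amine or a carboxylic acid on the ester chain, or a much longer chain, would give a clearly different number stays open, as compound 1, compound 2 and compound 3 carry only carbon groups on their esters. The shared core is also the same in all three, so these compounds say nothing about a change made there.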